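Aryl urea substituent swap: trifluoromethyl to ethyl

The source may report more compounds than this note shows. Statements on the series, on what has been measured and on what is new or still open speak of the compounds shown alone.

Compound 1 `Nc1cc(Oc2ccc(NC(=O)Nc3cccc(C(F)(F)F)c3)cc2)ncn1` gives 25 nM in an assay on isolated protein for inhibition of serine/threonine-protein kinase TNNI3K (Homo sapiens); a higher number here means a weaker inhibitor, a lower number a stronger inhibitor. Compound 2 `CNc1cc(Oc2ccc(NC(=O)Nc3cccc(C(F)(F)F)c3)cc2)ncn1` gives 40 nM in this assay; the step is a 1.6-fold higher number from compound 1 to compound 2 (0.20 log units; within the scatter). Compound 3 `CNc1cc(Oc2ccc(NC(=O)Nc3cccc(C(F)(F)F)c3)cc2C)ncn1` gives <= 10 nM in this assay, which is a limit of the assay and not a number. The step is an at least 4.0-fold lower number from compound 2 to compound 3 (0.60 log units; beyond the scatter); note (the limit of <= 10 nM in this assay, at which 1 of the 3 values shown sits). Among the numbers shown, compound 2 has the highest, with compound 1 nearest and within the scatter.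

Compound 4 `CCc1cccc(NC(=O)Nc2ccc(Oc3cc(NC)ncn3)cc2)c1` differs from compound 2 by ethyl in place of trifluoromethyl on an aromatic carbon. Neither measured step concerns this group; both involve methyl additions elsewhere on the core of compound 2, so they give no direct guide, and a step of uncertain size is expected. For compound 4 the expected value in this assay is 80 nM, within 25 nM to 300 nM. This estimate means an expected step of a 2.0-fold higher number from compound 2 to compound 4 (0.30 log units; within the scatter).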

Compound 4, half-maximal inhibitory concentration: 200 nM
For compound 4 the middle estimate is 2.5-fold (0.40 log units) below the measured one; the range from low to high includes it.
By their numbers in this assay, from the lowest: compounds 1 and 2 (each within the scatter of the next); then compound 4. At a limit, below all of these: compound 3.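

At this position on the ring of carbon only, the group matters in this assay: ethyl in place of trifluoromethyl gives a 5.0-fold higher number from compound 2 to compound 4 (0.70 log units; beyond the scatter), so here ethyl does not serve as a like-for-like replacement. The earlier steps shown here concerned other places on the core and did not test this group. Nothing shown accounts for the loss.

Open, as far as these compounds go, is how other groups at this position would compare, such as chlorine, methoxy or nitrile. Also open, from the compounds shown here alone, is whether the same swap carries the same cost on the core of compound 3.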